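The source may report more compounds than this note shows. Statements on the series, on what has been measured and on what is new or still open speak of the compounds shown alone.

In a functional assay on K562 cells (Homo sapiens) for antiproliferative activity, read by MTT assay, with a stated time of 48 h (on this read-out higher numbers stand for weaker inhibition and lower numbers for stronger inhibition), two compounds sharing one core have been measured so far. Compound 1, `COC(=O)[C@H](CC(C)C)NC(=O)c1ccc(Oc2nc3ccccc3nc2NC(C)(C)C)cc1`, gives > 50000 nM, which is a limit of the assay and not a number. Compound 2, `CC(C)(C)Nc1nc2ccccc2nc1Oc1ccc(C(=O)NCC(=O)O)cc1`, gives > 50000 nM, which is likewise a limit. Compound 2 therefore has no number of its own and stands at the limit of > 50000 nM in this assay, at which 2 of the 2 values shown sit.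

Compound 3, `C[C@H](NC(=O)c1ccc(Oc2nc3ccccc3nc2NC(C)(C)C)cc1)C(=O)O`, differs from compound 2 by methyl in place of hydrogen on a saturated chain carbon bound to an amide-type nitrogen and a carbonyl carbon. The carboxymethyl group thus becomes 1-carboxyethyl, while the rest of the structure stays the same.

Within the data shown here, only one measured step bears on this change, a step that the two limits leave unreadable from compound 1 to compound 2, and it offers no size to carry forward. Among the measured compounds shown here, no measured step covers the change from hydrogen to methyl. An expectation for this assay can rest only on the starting point, and that is weak because compound 2 stands at > 50000 nM, again a limit.

The expected result is a number no higher from compound 2 to compound 3 (the limit leaves the size open), with no change beyond the scatter in either direction. Compound 3 is estimated at about 50000 nM, within a range of 20000 nM to 100000 nM, and is expected most probably to be reported only as a limit.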

Compound 3, half-maximal inhibitory concentration: 26400 nM
Compound 3: the middle estimate sits 1.9-fold (0.28 log units) above what was measured; the range from low to high includes it.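

In this assay compound 3 is the only one of the three compounds shown that gives a number, 26400 nM, so methyl in place of hydrogen on this saturated chain carbon yields a step with a readable floor: an at least 1.8-fold lower number from compound 2 to compound 3 (0.27 log units; that floor lies within the scatter). Replacing 1-(methoxycarbonyl)-3-methylbutyl with 1-carboxyethyl on the amide-type nitrogen gives a floor of the same size, an at least 1.8-fold lower number from compound 1 to compound 3 (0.27 log units; that floor lies within the scatter), so neither step is shown to exceed the scatter, though either could be larger. These floors cannot be turned into sizes because compound 1 and compound 2 each give only a limit of the assay: the limit of > 50000 nM in this assay, at which 2 of the 3 values shown sit.

The step between compound 1 and compound 2 still cannot be read, so the compounds shown do not separate the effect of the carboxylic acid from that of the side chain, and a methyl ester carrying the same methyl side chain as compound 3 would be the direct comparison. Going by these compounds, whether a longer chain, such as ethyl or isobutyl, on the same carbon would move the value further also remains open.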